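Swapping an ester side chain for phenylethyl on the urea

The source may hold more compounds than are shown below. What is called first, only, known or untested is meant among the compounds shown, and "the series" means these compounds.

Compound 1 `CN1CC2(CCN(C(=O)Nc3cc(F)cc(F)c3)CC2)C1c1ccc(Cl)cc1` gives in an assay on HEK293 cells for inhibition of Voltage-dependent T-type calcium channel subunit alpha-1H (Homo sapiens), read by patch clamp, using a membrane potential dye (on this read-out lower numbers stand for stronger inhibition and higher numbers for weaker inhibition), the value 214 nM. Compound 2 `CC[C@H](C)[C@H](NC(=O)N1CCC2(CC1)CN(C(C)C)C2c1ccc(F)cc1)C(=O)OC` gives in this assay the value 256 nM. Compound 3 `CC[C@H](C)[C@H](NC(=O)N1CCC2(CC1)C(=O)N(c1cccc(F)c1)C2c1ccc(Cl)cc1)C(=O)OC(C)C` gives in this assay the value 45 nM.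

Compound 3 has the lowest of the three numbers, and its gaps to compound 1 and to compound 2 both lie beyond the usual scatter. Compound 4 `C[C@@H](NC(=O)N1CCC2(CC1)C(=O)N(c1cccc(F)c1)C2c1ccc(Cl)cc1)c1ccccc1` is the untested analogue. It differs from compound 3 in one place: a group of 8 heavy atoms (8 carbon; one six-membered aromatic ring of carbon only) in place of a group of 11 heavy atoms (9 carbon, 2 oxygen; no ring), on an amide-type nitrogen. Whether a urea substituent of this kind changes the number is not shown by any tested pair, so the step from compound 3 to compound 4 in this assay is expected to stay within the scatter or lean slightly weaker, as a 1.8-fold higher number from compound 3 to compound 4 (0.25 log units; within the scatter) states. Compound 4 is therefore estimated at 80 nM, with a range from 25 nM to 250 nM.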

Compound 4, half-maximal inhibitory concentration: 351 nM
Compound 4: middle estimate off by 4.4-fold (0.64 log units), on the low side, and the stated range ends below it.
By their numbers in this assay, from the lowest: compound 3; then compounds 1, 2 and 4 (each within the scatter of the next).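

In this assay, among these compounds, replacing the ester side chain on the amide-type nitrogen with 1-phenylethyl gives a 7.8-fold higher number from compound 3 to compound 4 (0.89 log units; beyond the scatter) and is the first change here made with the rest of the molecule held constant. It shows that the number depends on the group at this position, and that an aromatic ring in this 1-phenylethyl form does not match the ester side chain of compound 3. Nothing measured here explains the difference.

Going by these compounds, it remains open whether the ester itself or the rest of the side chain accounts for the step. A carboxylic acid or a primary amide in place of the ester, or a benzyl group in place of 1-phenylethyl, would help separate these possibilities.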